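A few compounds are considered here, and "the series" means these few. Any claim that something is new, unique, unknown or untested is made for them only; others in the source may bear on it.

Compound 1 `O=C(O)CS(=O)(=O)c1ccc(OCc2cccc(-c3ccccc3Cl)c2)cc1`: 28.8 nM
Compound 2 `Cc1ccc(-c2cccc(COc3ccc(S(=O)(=O)CC(=O)O)cc3)c2)c(Cl)c1`: 36.3 nM
Compound 3 `O=C(O)CS(=O)(=O)c1cccc(OCc2ccc(-c3ccccc3)cc2)c1`: > 1000 nM

Of the compounds shown here, three have been measured in a functional assay on CHO cells for agonist activity at Free fatty acid receptor 1 (Homo sapiens), read by FLIPR and calcium flux; a lower number here means that less compound is needed, a higher number that more compound is needed for the effect. Compound 1 gives 28.8 nM, and compound 2 gives 36.3 nM. For compound 3 the assay reports only a limit, > 1000 nM. Compound 2 differs from compound 1 by methyl in place of hydrogen on an aromatic carbon, and that step was a 1.3-fold higher number from compound 1 to compound 2 (0.10 log units; within the scatter). The difference between the cores of compound 1 and compound 3 is not broken down here.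

Compound 4 `Cc1ccccc1-c1ccc(COc2cccc(S(=O)(=O)CC(=O)O)c2)cc1` has not yet been measured. It differs from compound 3 by methyl in place of hydrogen on an aromatic carbon, the same kind of change as from compound 1 to compound 2, though there the methyl sits meta to a chloro group and para to a large group, while here it sits ortho to a large group. Resting on the earlier step, which stayed within the scatter, and on the limit of > 1000 nM in this assay, at which 1 of the 3 values shown sits, at which compound 3 sits, compound 4 is expected to move by a step that the limit leaves unreadable from compound 3 to compound 4. For compound 4 the estimate is 1500 nM, expected to fall between 300 nM and 6000 nM.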

Compound 4, half-maximal effective concentration: > 1000 nM
Compound 4: a limit, no number; the forecaster's own chance of this, stated with the estimate: 60%; the middle value lies beyond the limit too.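

Compound 3 and compound 4 each give a limit, not a number, so no step between them can be read in this assay: the limit of > 1000 nM in this assay, at which 2 of the 4 values shown sit.

The compounds shown leave open whether going from phenyl to 2-methylphenyl changes the response on the core of compound 3 at all.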